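The source may hold more compounds than are shown below. What is called first, only, known or untested is meant among the compounds shown, and "the series" means these compounds.

Measured so far:
compound 1, `CCC(=O)c1ccc(OCCCCOc2ccc(F)c(C(=O)O)c2)c(C)c1O`: 35%
compound 2, `Cc1c(OCCCCOCOc2ccc(C(=O)O)cc2)ccc(C(=O)CC2CCCC2)c1O`: 31%
compound 3, `Cc1cc(OCCCCOc2ccc(C(=O)CC3CCCC3)c(O)c2C)ccc1C(=O)O`: 55%

In an ADME assay (liver) for metabolic stability, with Liver microsome (Rattus norvegicus) as the target, read by LC-MS, using microsomes and NADPH, with stated times of 5 min and 60 min, tested at 4 uM (a higher number here means that more of the compound is left, a lower number that less of the compound is left), compound 3 stands highest of the three; compound 1 is nearest, and compound 2 lies furthest, the step of a number 24 percentage points higher from compound 2 to compound 3 (beyond the scatter) having been the only measured change among these compounds. Compound 4, `Cc1c(OCCCCOc2ccc(C(=O)O)c(Cl)c2)ccc(C(=O)CC2CCCC2)c1O`, differs from compound 3 by chloro in place of methyl on an aromatic carbon, ortho to a carboxy group. Within the data shown here, no measured step exchanges a methyl for a chloro, so none bears directly on this change; the one step seen alters the linkage instead. A step of at most moderate size in this assay is therefore expected for compound 4, with no firm direction, as a number 10 percentage points lower from compound 3 to compound 4 (within the scatter). Compound 4 is estimated at 45%, in a range from 28% to 62%.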

Compound 4, percent of the compound remaining: 67%
Beside the measured number, compound 4's estimate is 22 percentage points below it, and the stated range ends below it.
By their numbers in this assay, from the lowest: compounds 2 and 1 (each within the scatter of the next); then compound 3; then compound 4.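

In this assay, the aromatic carbon ortho to a carboxy group proves sensitive to a single-atom exchange: chloro in place of methyl gives a number 12 percentage points higher from compound 3 to compound 4 (beyond the scatter). The earlier compounds shown here showed only a change in the linkage, and replacing that whole end group gives a number 36 percentage points higher from compound 2 to compound 4 (beyond the scatter), a large step. No measurement here explains why more of compound 4 remains. Going by these compounds, whether bromo or trifluoromethyl at this place would leave a similar amount of compound remains open. So does whether chloro would give a step of similar size with a different group on the ketone carbonyl.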